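From compound 3 to compound 4: replacing the iodo group

This account rests on a few compounds, and the source may have more. Where it says the series, first, only, none or still open, it means among the compounds named here.

In a functional assay on SK-OV-3 cells (Homo sapiens) for antiproliferative activity, read by MTT assay, with a stated time of 72 h (a higher number here means a weaker inhibitor, a lower number a stronger inhibitor), compound 1 `CCNC(=O)CCc1cccc2c1B(O)OC2` gives > 100000 nM, which is a limit of the assay. Compound 2 `CC(C)(C)NC(=O)CCc1cccc2c1B(O)OC2` gives > 100000 nM, again a limit. Within the data shown here, compound 3 `O=C(CCc1cccc2c1B(O)OC2)Nc1ccc(I)cc1` gives 51000 nM, the only actual number so far. Compound 4 `CC(C)(C)OC(=O)NCc1ccc(NC(=O)CCc2cccc3c2B(O)OC3)cc1` carries ((tert-butoxycarbonyl)amino)methyl in place of iodo on an aromatic carbon, para to a large group: ((tert-butoxycarbonyl)amino)methyl in place of iodo on an aromatic carbon. The measured steps that bear on this are an at least 1.9-fold lower number from compound 1 to compound 3 (0.29 log units; that floor lies within the scatter) and an at least 1.9-fold lower number from compound 2 to compound 3 (0.29 log units; that floor lies within the scatter), both with floors within the scatter, and neither is a change at that aromatic carbon alone. No step beyond the scatter is therefore expected in this assay, and the expected step is a 1.2-fold higher number from compound 3 to compound 4 (0.07 log units; within the scatter). For compound 4 the estimated value is 60000 nM, with an expected range of 25000 nM to 130000 nM.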

Compound 4, half-maximal inhibitory concentration: 2000 nM
For compound 4 the middle estimate is 30-fold (1.48 log units) above the measured one, outside the stated range (below it).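

Among these compounds, the aromatic carbon para to a large group is the first place where one change moves the read-out beyond the scatter: in this assay there is a 26-fold lower number from compound 3 to compound 4 (1.41 log units; beyond the scatter). Among the compounds shown here, this single-place change, ((tert-butoxycarbonyl)amino)methyl in place of iodo, shows that this position affects the read-out, which the earlier steps, with floors within the scatter, could not show. Readable values remain few in the series: the limit of > 100000 nM in this assay, at which 2 of the 4 values shown sit.

Which part of the entering group carries this step stays open. A free aminomethyl, a hydroxymethyl or a plain methyl on the same carbon would separate its parts.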